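Cytotoxicity and the amine substituent on a shared nucleoside core

The compounds below may be only part of what the source reports. "The series", "measured", "known", "first", "only" and "open" are said of these compounds alone.

Measured compounds in a functional assay on HEL cells (Homo sapiens); on this read-out higher numbers stand for lower toxicity in this test and lower numbers for higher toxicity in this test:
compound 1 `Cc1cn([C@@H]2O[C@H](CO[Si](C)(C)C(C)(C)C)[C@@]3(OS(=O)(=O)C=C3NCC(=O)C(=O)N3CCC3)[C@H]2O[Si](C)(C)C(C)(C)C)c(=O)n(C)c1=O`: 84400 nM
compound 2 `C=C(C)C(=O)NC(=O)NC1=CS(=O)(=O)O[C@@]12[C@@H](CO[Si](C)(C)C(C)(C)C)O[C@@H](n1cc(C)c(=O)n(C)c1=O)[C@@H]2O[Si](C)(C)C(C)(C)C`: 1200 nM

Among the compounds with values here, on these two numbers compound 2 stands lowest in this assay, with compound 1 as its only neighbour at a clearly higher number. Compound 3 `Cc1cn([C@@H]2O[C@H](CO[Si](C)(C)C(C)(C)C)[C@@]3(OS(=O)(=O)C=C3NCC(=O)C(N)=O)[C@H]2O[Si](C)(C)C(C)(C)C)c(=O)n(C)c1=O` has not yet been measured. It differs from compound 2 in one place: (carbamoylcarbonyl)methyl in place of ((1-methylethenyl)carbonyl)carbamoyl on an amine nitrogen. Within the data shown here, the only measured step that bears on this change is a 70-fold lower number from compound 1 to compound 2 (1.85 log units; beyond the scatter), which moved away from a (((azetidin-1-yl)carbonyl)carbonyl)methyl side chain towards the one now present in compound 2. The change to compound 3 runs in the opposite sense, back towards a chain of the kind carried by compound 1, so a large step towards a higher number in this assay is expected. For compound 3 the estimated value is 40000 nM, within a range of 8000 nM to 150000 nM, which amounts to an expected step of a 33-fold higher number from compound 2 to compound 3 (1.52 log units; beyond the scatter).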

Compound 3, half-maximal cytotoxic concentration: 14500 nM
For compound 3 the middle estimate is 2.8-fold (0.44 log units) above the measured one, and the stated range covers the measured number.
By their numbers in this assay, from the lowest: compound 2; then compound 3; then compound 1.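

In this assay, the change on the amine nitrogen from ((1-methylethenyl)carbonyl)carbamoyl to (carbamoylcarbonyl)methyl gives a 12-fold higher number from compound 2 to compound 3 (1.08 log units; beyond the scatter) and so shows that the low number of compound 2 can be largely reversed by a change at this position alone, with the rest of the core unchanged. The result also shows that the far end of the (carbonyl)methyl chain matters: amino in place of azetidin-1-yl on a carbonyl carbon gives a 5.8-fold lower number from compound 1 to compound 3 (0.76 log units; beyond the scatter) in this assay and thus separates two chains of the same kind, something the earlier pair could not do.

Going by these compounds, it remains open whether a methylamine or a piperidine on that carbonyl carbon would give a number nearer that of compound 1 or compound 3. Nothing measured here accounts for either step.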